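The source may hold more compounds than are shown below. What is called first, only, known or untested is meant among the compounds shown, and "the series" means these compounds.

Measured compounds:
compound 1 `CC(C)n1nc(-c2ccc3oc(N)nc3c2)c2c(Cl)nc(N)nc21` – 92%
compound 2 `CC(C)n1nc(-c2ccc3oc(N)nc3c2)c2c(Br)nc(N)nc21` – 94%

Both values come from an ADME assay on microsomes from liver (Homo sapiens) for metabolic stability, read by LC-MS, with a stated time of 15 min, tested at 1 uM, in the presence of a further agent that is not named here; on this read-out higher numbers stand for a more stable compound and lower numbers for a less stable compound. Among the two numbers, compound 2 holds the higher one, with compound 1 nearest; the gap a number 2 percentage points higher from compound 1 to compound 2 (within the scatter) is within the scatter, so the two compounds cannot be ranked against each other on this read-out.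

Compound 3 `CC(C)n1nc(-c2ccc3oc(N)nc3c2)c2cnc(N)nc21` has not yet been measured in this assay. It differs from compound 2 in one place: hydrogen in place of bromo on an aromatic carbon. Among the measured compounds shown here, the only measured step, chloro to bromo at this same position, gave a number 2 percentage points higher from compound 1 to compound 2 (within the scatter), which is within the scatter. For the measured compounds named here, no measured step removes a halogen altogether, so the change to compound 3 has no direct precedent here; the only guidance is that both halogenated compounds sit high on the read-out and that swapping one halogen for the other left the number essentially unchanged.

Going by the values given here, on that basis the step of a number 6 percentage points lower from compound 2 to compound 3 (within the scatter) is expected to stay within the scatter, with a wide band of uncertainty because no step tests this change directly. Compound 3 is estimated at 88% in this assay, with a range from 72% to 98%.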

Compound 3, percent of the compound remaining: 94%
Compound 3: the middle estimate sits 6 percentage points below what was measured, within the range that was stated.
By their numbers in this assay, from the lowest: compounds 1, 2 and 3 (each within the scatter of the next).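

In this assay the series now includes a compound with hydrogen on the aromatic carbon next to the ring nitrogen: replacing bromo gives no change at the digits printed from compound 2 to compound 3 (within the scatter) and replacing chloro gives a number 2 percentage points higher from compound 1 to compound 3 (within the scatter) on the same read-out. The earlier pair compared only one halogen with another, so it could not show whether a halogen on this carbon matters at all; hydrogen, chloro and bromo now cannot be told apart in this assay. Among these three compounds, a halogen at this position is therefore not needed for a high number, and compound 3 serves as the plain reference for further changes on this carbon.

It remains open whether an amine, a carboxylic acid or a longer chain on this carbon would give a number in the same range, since all three substituents shown are single atoms. On these data alone, it is also open whether the same indifference to hydrogen, chloro and bromo would hold with a different group on the rest of the shared core. Nothing available here bears on why these three substituents cannot be separated on this read-out.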